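Methoxy step carried from one shared core to another

A few compounds are considered here, and "the series" means these few. Any claim that something is new, unique, unknown or untested is made for them only; others in the source may bear on it.

Compound 1 `CC(=O)Nc1ccc(O)c(C(=O)/C=C/c2ccccc2)c1` and compound 2 `COc1cccc(/C=C/C(=O)c2cc(NC(C)=O)ccc2O)c1` share one core; compound 3 `CC(=O)Nc1ccc2oc(-c3ccccc3)cc(=O)c2c1` and compound 4 `COc1ccccc1-c1cc(=O)c2cc(NC(C)=O)ccc2o1` share another. The difference between the two cores is not broken down here. In an ADME assay on MT4 cells (Homo sapiens) for cytotoxicity, read by MTT assay, with a stated time of 4 days (on this read-out lower numbers stand for higher toxicity in this test and higher numbers for lower toxicity in this test), compound 1 gives 49400 nM, compound 2 gives 40000 nM and compound 3 gives 184000 nM, the highest number of the three measured. The change methoxy in place of hydrogen on an aromatic carbon made the step of a 1.2-fold lower number from compound 1 to compound 2 (0.09 log units; within the scatter). The change methoxy in place of hydrogen on an aromatic carbon is the same kind of change, but the entering group stands ortho to a large group in compound 4, whereas in compound 2 it stands meta to a large group. The step is expected to be a 1.2-fold lower number from compound 3 to compound 4 (0.09 log units; within the scatter), since the same kind of change earlier gave a 1.2-fold lower number from compound 1 to compound 2 (0.09 log units; within the scatter). Compound 4 is therefore expected at about 150000 nM, within 60000 nM to 400000 nM.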

Compound 4, half-maximal cytotoxic concentration: 226000 nM
For compound 4 the middle estimate is 1.5-fold (0.18 log units) below the measured one; the measured number falls inside the stated range.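

In this assay, methoxy in place of hydrogen on an aromatic carbon gives a 1.2-fold higher number from compound 3 to compound 4 (0.09 log units; within the scatter), so on this core too the step stays within the scatter. The two steps agree across the two cores: the same change on two cores in this assay, a 1.2-fold lower number (0.09 log units; within the scatter) from compound 1 to compound 2 and a 1.2-fold higher number (0.09 log units; within the scatter) from compound 3 to compound 4, 1.5-fold (0.18 log units) apart, within the scatter of two such steps. This shows that, for these two pairs and in this read-out alone, the change carries from one core to the other without a step beyond the scatter, but it does not separate the place of the methoxy from the core, as both differ together, and it says nothing about other cores.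

Still open, going by these compounds, is whether an amine or a carboxylic acid in place of the methoxy would give a step beyond the scatter on either core. The same question stands for a longer chain such as ethoxy.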